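Second methylsulfanyl on the shared core: clearance notes

The source may report more compounds than this note shows. Statements on the series, on what has been measured and on what is new or still open speak of the compounds shown alone.

Three compounds of the series have numbers in an ADME assay on microsomes from liver (Mus musculus) for metabolic stability; a lower number here means slower removal, a higher number faster removal of the compound. Compound 1 `CCOc1cc([C@](O)(CCN(C)C)[C@@H](c2cc3cc(Br)ccc3nc2OC)c2cccc(OC)c2F)cc(OC)n1` gives 14 uL/min. Compound 2 `COc1cc([C@](O)(CCN(C)C)[C@@H](c2cc3cc(Br)ccc3nc2OC)c2cccc(OC)c2F)cc(OC(F)F)n1` gives 6.4 uL/min, and compound 3 `COc1cc([C@](O)(CCN(C)C)[C@@H](c2cc3cc(Br)ccc3nc2OC)c2cccc(OC)c2F)cc(SC)n1` gives 20 uL/min. Compound 3 carries the highest of the three numbers, but its gap to compound 1 is within the scatter, as a 1.4-fold higher number from compound 1 to compound 3 (0.15 log units; within the scatter) shows; only a 3.1-fold higher number from compound 2 to compound 3 (0.49 log units; beyond the scatter) lies beyond it, and a 2.2-fold lower number from compound 1 to compound 2 (0.34 log units; beyond the scatter) separates the remaining pair.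

Compound 4 `COc1cccc([C@H](c2cc3cc(Br)ccc3nc2OC)[C@@](O)(CCN(C)C)c2cc(SC)nc(SC)c2)c1F` is the next step from compound 3: methylsulfanyl in place of methoxy on an aromatic carbon, the entering group sitting next to the ring nitrogen and meta to the methylsulfanyl group already present. Within the data shown here, two measured steps bear on this change, each bringing a methylsulfanyl group onto the same ring. The closer one, a 1.4-fold higher number from compound 1 to compound 3 (0.15 log units; within the scatter), exchanges ethoxy for methylsulfanyl and stays within the scatter; the other, a 3.1-fold higher number from compound 2 to compound 3 (0.49 log units; beyond the scatter), starts from difluoromethoxy and is modest. Methoxy resembles ethoxy more than difluoromethoxy, so a step toward a higher number is expected in this assay, but a small one, most likely within the scatter, a 1.3-fold higher number from compound 3 to compound 4 (0.11 log units; within the scatter). For compound 4 the expected number is 26 uL/min, with a range from 13 uL/min to 52 uL/min.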

Compound 4, intrinsic clearance in a liver preparation (reported as CLH), per the amount of preparation that the assay uses: 17 uL/min
The estimate for compound 4 lay 1.5-fold (0.18 log units) above the measured number, within the range that was stated.
By their numbers in this assay, from the lowest: compound 2; then compounds 1, 4 and 3 (each within the scatter of the next).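

In this assay, methylsulfanyl in place of methoxy next to the ring nitrogen, on a ring that already has a methylsulfanyl group, gives a step within the scatter (a 1.2-fold lower number from compound 3 to compound 4 (0.07 log units; within the scatter)), so this position now has a reading with a second methylsulfanyl group present. The ring bearing two methylsulfanyl groups also stays within the scatter of the ring bearing ethoxy and methoxy (a 1.2-fold higher number from compound 1 to compound 4 (0.08 log units; within the scatter)), but remains apart from the ring bearing methoxy and difluoromethoxy (a 2.7-fold higher number from compound 2 to compound 4 (0.42 log units; beyond the scatter)), which leaves compound 2 as the only one of the four whose steps to all the others lie beyond the scatter, with compounds 1, 3 and 4 close together. No measurement among these compounds accounts for these numbers.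

Whether difluoromethoxy would keep compound 2 apart when it sits on the ring together with methylsulfanyl remains open, since the two groups share a ring in none of the compounds shown. Also open, on these data alone, is how this position responds to an amine such as dimethylamino, or to a longer chain such as propoxy, in place of methylsulfanyl.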